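From 2-methoxyphenyl to 3-methoxyphenyl on a sulfonamide nitrogen

The source may hold more compounds than are shown below. What is called first, only, known or untested is meant among the compounds shown, and "the series" means these compounds.

Compound 1 `O=C1NCCN1c1ccc(S(=O)(=O)Nc2cccc(Oc3ccccc3)c2)cc1`: 200 nM
Compound 2 `COc1ccccc1NS(=O)(=O)c1ccc(N2CCNC2=O)cc1`: 550 nM

Both values come from a functional assay on HT-29 cells (Homo sapiens) for antiproliferative activity, read by sulforhodamine B assay, with a stated time of 48 h; on this read-out higher numbers stand for weaker inhibition and lower numbers for stronger inhibition. Of the two, compound 2 has the higher number, so it is the weaker inhibitor, and its gap to compound 1 lies beyond the usual scatter of repeated measurements.

The next compound to be tested is compound 3 `COc1cccc(NS(=O)(=O)c2ccc(N3CCNC3=O)cc2)c1`. It has the same atoms as compound 2, joined differently: 3-methoxyphenyl in place of 2-methoxyphenyl on a sulfonamide nitrogen. In plain terms, 3-methoxyphenyl stands in place of 2-methoxyphenyl on a sulfonamide nitrogen, and the rest of the molecule stays the same.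

Going by the values given here, no measured pair of compounds here differs in a single place, so the data offer no direct guide to what this change does. The best starting point is compound 2 at 550 nM, the closest relative of the new compound. A small step in this assay is expected, no larger than the usual scatter and with no firm direction. The estimated change is a 1.1-fold lower number from compound 2 to compound 3 (0.04 log units; within the scatter). For compound 3 the expected value is 500 nM, with an estimated range from 150 nM to 1600 nM.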

Compound 3, half-maximal inhibitory concentration: 120 nM
Compound 3: the middle estimate sits 4.2-fold (0.62 log units) above what was measured; the measured number lies below the stated range.
By their numbers in this assay, from the lowest: compounds 3 and 1 (each within the scatter of the next); then compound 2.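

In this assay, the step from 2-methoxyphenyl to 3-methoxyphenyl on the sulfonamide nitrogen gives a 4.6-fold lower number from compound 2 to compound 3 (0.66 log units; beyond the scatter), which lies beyond the usual scatter. Both groups have the same atoms and the same counts, so this pair shows that how the group is joined can change the result on its own, something the two earlier compounds could not show because they differ in more than one place. The second step, a 1.7-fold lower number from compound 1 to compound 3 (0.22 log units; within the scatter), has methyl in place of phenyl on an oxygen on an aromatic ring and stays within the scatter, so this assay does not separate those two compounds, even though the group on that oxygen differs greatly in size. Nothing measured here bears on why the two methoxyphenyl compounds differ.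

The compounds shown leave open whether that oxygen needs a carbon group on it at all, as a hydroxyl there would test, and whether an ethyl or a longer chain would fit as well as methyl and phenyl do. They also leave open whether the oxygen itself matters, which a chlorine or an amine in its place would help to settle.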